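From phenyl to 4-methoxyphenyl: one small change

This account rests on a few compounds, and the source may have more. Where it says the series, first, only, none or still open, it means among the compounds named here.

Measured so far in a functional assay on HCT-116 cells (Homo sapiens) for cytotoxicity, read by MTT assay, with a stated time of 72 h (on this read-out lower numbers stand for stronger inhibition and higher numbers for weaker inhibition), are these compounds:
compound 1 `COc1ccc(S(=O)(=O)c2nc3ccccc3nc2N2CCCC2)cc1` gives > 50000 nM as a limit of the assay
compound 2 `COc1ccc(S(=O)(=O)c2nc3ccccc3nc2N2CCc3ccccc3C2)cc1` gives 22100 nM
compound 3 `O=S(=O)(c1ccccc1)c1nc2ccccc2nc1N1CCC(O)CC1` gives 1870 nM

Of the two true numbers, compound 2 has the higher (22100 nM) and compound 3 the lower (1870 nM). The reading for compound 1 is only a limit.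

Compound 4 `COc1ccc(S(=O)(=O)c2nc3ccccc3nc2N2CCC(O)CC2)cc1` differs from compound 3 in one place methoxy in place of hydrogen on an aromatic carbon with methoxy in place of hydrogen, so that phenyl becomes 4-methoxyphenyl. Going by the values given here, no measured step shows this change directly. Among the compounds with values here, the only measured step, an at least 2.2-fold lower number from compound 1 to compound 2 (0.35 log units; beyond the scatter), exchanges a different group, and both of its compounds already carry 4-methoxyphenyl. It shows that the number can move with that other group, so it says little about methoxy itself. Compound 2 (22100 nM) carries 4-methoxyphenyl and sits higher than compound 3, but it differs in the other group too, so it only tilts the expectation towards a higher number. A modest rise is therefore expected, and the expected size is a 1.6-fold higher number from compound 3 to compound 4 (0.21 log units; within the scatter) in this assay as a rough estimate. For compound 4 the estimated value is 3000 nM with an expected range (800 nM to 12000 nM).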

Compound 4, half-maximal inhibitory concentration: 4690 nM
Beside the measured number, compound 4's estimate is 1.6-fold (0.19 log units) below it; low and high end bracket the measured number.
By their numbers in this assay, from the lowest: compound 3; then compound 4; then compound 2. At a limit, above all of these: compound 1.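

In this assay, the change from phenyl to 4-methoxyphenyl now has a direct reading with 4-hydroxypiperidin-1-yl held fixed: it is a 2.5-fold higher number from compound 3 to compound 4 (0.40 log units; beyond the scatter), so at this position hydrogen gives the lower number of the two. With 4-methoxyphenyl held fixed, bringing in 4-hydroxypiperidin-1-yl gives a 4.7-fold lower number from compound 2 to compound 4 (0.67 log units; beyond the scatter) and an at least 10-fold lower number from compound 1 to compound 4 (1.02 log units; beyond the scatter), and both of these steps run towards a lower number, opposite in direction to the methoxy step. The reading for compound 1 behind that last step is a limit and not a number: the limit of > 50000 nM in this assay, at which 1 of the 4 values shown sits.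

The compounds shown give the methoxy step on a single background, so it remains open whether it would keep its direction with pyrrolidin-1-yl or 1,2,3,4-tetrahydroisoquinolin-2-yl as the other group. As far as these compounds go, it also remains open how a fluorine, a nitrile, an amine or a longer ether such as ethoxy would read on the same aromatic carbon, and so whether the rise belongs to methoxy alone or would be shared by other groups placed there.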